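The compounds below may be only part of what the source reports. "The series", "measured", "known", "first", "only" and "open" are said of these compounds alone.

Compound 1 `CCCc1nc(C)c2c(C3CC3)nnc(O)n12`: in a functional assay for inhibition, with Homo sapiens as the target (on this read-out higher numbers stand for weaker inhibition and lower numbers for stronger inhibition), compound 1 reaches only the assay limit of > 48000 nM.
Compound 2 `Oc1nncc2cnc(Cc3ccccc3)n12`: in this assay compound 2 likewise reaches only the assay limit of > 48000 nM.

Compound 1 therefore stands where every value shown stands, at the limit of > 48000 nM in this assay, at which 2 of the 2 values shown sit, and neither compound yields a number. Compound 3 `CCCCc1nnc(O)n2c(CCC)nc(C)c12` differs from compound 1 by butyl in place of cyclopropyl on an aromatic carbon. For the measured compounds named here, no step between two measured compounds is available to gauge this change. Given that compound 1 sits at the limit of > 48000 nM in this assay, at which 2 of the 2 values shown sit, the step from compound 1 to compound 3 is expected to be none beyond the scatter, estimated as a step that the limit leaves unreadable from compound 1 to compound 3. Compound 3 is accordingly expected to give about 50000 nM, estimated between 15000 nM and 200000 nM, most likely once more only as a limit.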

Compound 3, half-maximal inhibitory concentration: > 48000 nM
Compound 3 gave a limit, no number (the forecaster's own chance of this, stated with the estimate: 80%); the middle value does not contradict the limit.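

For the compounds shown here, no step from compound 1 to compound 3 can be read, since both compounds give only a limit: the limit of > 48000 nM in this assay, at which 3 of the 3 values shown sit. The compounds shown leave open what change to the shared core, if any, would give a number in this assay.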